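From Compound 2 to Compound 4: An Expected Lipophilicity

This account rests on a few compounds, and the source may have more. Where it says the series, first, only, none or still open, it means among the compounds named here.

Values so far in a physicochemical assay for lipophilicity, read by HPLC, at pH 7.5 (on this read-out lower numbers stand for lower lipophilicity and higher numbers for higher lipophilicity), are
- compound 1 `CCOc1ccccc1-c1ccc(-c2nc3cnccc3c(N[C@H](CC)C(=O)NS(C)(=O)=O)c2C#N)cc1` at 2.2
- compound 2 `CCOc1ccccc1-c1ccc(-c2nc3cnccc3c(C[C@H](C)C(N)=O)c2C#N)cc1` at 3
- compound 3 `CC[C@@H](Nc1c(C#N)c(-c2ccc(-c3cccc(C)c3F)cc2)nc2cnccc12)C(=O)O` at 2.1

Compound 2 stands highest of the three, clear of the usual scatter. Compound 4 `CCOc1ccccc1-c1ccc(-c2nc3cnccc3c(N[C@@H]3CCOC3=O)c2C#N)cc1` differs from it by (2-oxooxolan-3-yl)amino in place of 2-carbamoylpropyl on an aromatic carbon and the new group sits opposite the ring nitrogen. One measured step also swaps a group on an aromatic carbon, namely a number 0.80 log units higher from compound 1 to compound 2 (beyond the scatter) and it involves other groups. It therefore shows how far such a swap can move the number, not which way this one will go. The estimated step in this assay is a number 0.20 log units higher from compound 2 to compound 4 (within the scatter) with no change beyond the scatter expected. For compound 4 the expected value is 3.2 with an estimated range from 2.6 to 3.8 until it is measured.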

Compound 4, distribution coefficient: 2.7
The estimate for compound 4 lay 0.50 log units above the measured number; the range from low to high includes it.
By their numbers in this assay, from the lowest: compounds 3 and 1 (each within the scatter of the next); then compounds 4 and 2 (each within the scatter of the next).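

In this assay, the step of a number 0.30 log units lower from compound 2 to compound 4 (within the scatter) shows that, at this position opposite the ring nitrogen, (2-oxooxolan-3-yl)amino can replace 2-carbamoylpropyl without a change beyond the scatter, even though the swap brings in a five-membered non-aromatic ring. With the nitrogen on the aromatic ring kept, the step of a number 0.50 log units higher from compound 1 to compound 4 (beyond the scatter) shows that the group attached to that nitrogen can still move the number. Still open, on these data alone, is whether a longer chain or a plain amine here would also stay within the scatter of compound 2, and no measured evidence explains either step.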